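Urea to pyridinyl amide at the shared core

The source may report more compounds than this note shows. Statements on the series, on what has been measured and on what is new or still open speak of the compounds shown alone.

The series rests on a shared core that carries an amide-type nitrogen bearing a carbonyl group, with a basic amide on the other side of the core. Compound 1 `CN1CCC(C(=O)N2Cc3c(NC(=O)Nc4cccc(F)c4)n[nH]c3C2(C)C)CC1` gives 350 nM in a functional assay on A2780 cells (Homo sapiens) for antiproliferative activity, read by fluorescence, with a stated time of 72 h; on this read-out lower numbers stand for stronger inhibition and higher numbers for weaker inhibition. Compound 2 `CN1CCC(C(=O)Nc2n[nH]c3c2CN(C(=O)C(C)(C)C)C3(C)C)CC1`, which keeps the same amine side chain but puts it on the other end of the core, gives 350 nM in this assay, level with compound 1 within the scatter. Compound 3 `CC(=O)N1CCN(C(=O)N2Cc3c(NC(=O)c4ccc(F)cc4)n[nH]c3C2(C)C)CC1`, which replaces the urea with a benzamide and exchanges the amine for an acetylated piperazine, reaches only the limit of this assay, at > 10000 nM; its value is a limit rather than a number (the limit of > 10000 nM in this assay, at which 1 of the 3 values shown sits).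

Compound 4 `CN1CCC(C(=O)N2Cc3c(NC(=O)c4ccncc4)n[nH]c3C2(C)C)CC1` is to be measured. It differs from compound 1 in one place: pyridin-4-yl in place of (3-fluorophenyl)amino on a carbonyl carbon.

For the measured compounds named here, no step between measured compounds matches this change, and the only other amide in the set, compound 3, carries a second alteration as well, so it cannot be read alone. The change at hand exchanges a urea for an amide and removes the hydrogen-bond donor of the (3-fluorophenyl)amino group. Compound 4 is therefore expected to be weaker than compound 1 by a step of a 4.3-fold higher number from compound 1 to compound 4 (0.63 log units; beyond the scatter) that reaches beyond the scatter, with an estimate of 1500 nM and a range from 300 nM to 10000 nM.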

Compound 4, half-maximal inhibitory concentration: 500 nM
Compound 4: the middle estimate sits 3.0-fold (0.48 log units) above what was measured; measured number inside the range.
By their numbers in this assay, from the lowest: compounds 1, 2 and 4 (each within the scatter of the next). At a limit, above all of these: compound 3.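

For the compounds shown here, exchanging (3-fluorophenyl)amino for pyridin-4-yl on a carbonyl carbon gives a 1.4-fold higher number from compound 1 to compound 4 (0.15 log units; within the scatter) in this assay, the first reading of any change at this position. In this pair, the urea is therefore not needed to hold the level of compound 1, and the pyridin-4-yl amide serves as well within the scatter, even though the hydrogen-bond donor of the (3-fluorophenyl)amino group is gone. Compound 3 also carries an amide on this carbonyl carbon but differs from compound 4 in a second place, so it offers no direct comparison and remains a limit, not a number: the limit of > 10000 nM in this assay, at which 1 of the 4 values shown sits.

This single pair changes the linking nitrogen and the ring at once, so it cannot separate what each contributes to the level in this assay. As far as these compounds go, it remains open how the amide would read with a plain phenyl ring, a pyridin-3-yl ring or a cyclohexyl ring on the same carbonyl carbon, and whether a urea carrying pyridin-4-yl would stay at the same level.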